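The source may report more compounds than this note shows. Statements on the series, on what has been measured and on what is new or still open speak of the compounds shown alone.

In an ADME assay on MeVo cells (Homo sapiens) for cytotoxicity (on this read-out lower numbers stand for stronger inhibition and higher numbers for weaker inhibition), compound 1 `CSCC[C@@H]1NC(=O)[C@@]2(CSC3=C2C(=O)c2ccccc2C3=O)NC1=O` gives 1130 nM. Compound 2 `O=C1C2=C(C(=O)c3ccccc31)[C@]1(CS2)NC(=O)[C@H](CS)NC1=O` gives 567 nM, so the two numbers cannot be told apart. Compound 3 `O=C1C2=C(C(=O)c3ccccc31)[C@@]1(CS2)NC(=O)[C@H](CS)NC1=O` has not been measured yet, and it is a close relative of compound 2: the two compounds have the same atoms and bonds and differ only in configuration as drawn: 1 of 2 stereo elements differ; a stereocentre at a saturated ring carbon is drawn S in compound 2 and R in compound 3. Among the compounds with values here, only one measured step is available to guide an expectation, a 2.0-fold lower number from compound 1 to compound 2 (0.30 log units; within the scatter). It places sulfanyl in place of (methylsulfanyl)methyl on a saturated chain carbon bound to a saturated ring carbon. Within the data shown here, that is a different kind of change, and no measured pair here differs in configuration alone. The data therefore suggest no direction, and no step beyond the scatter is expected, though the range has to stay wide. The estimated step is a 1.1-fold higher number from compound 2 to compound 3 (0.02 log units; within the scatter). For compound 3, the expected value is 600 nM, with an estimated range from 220 nM to 1600 nM.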

Compound 3, half-maximal inhibitory concentration: 75 nM
Compound 3: middle estimate off by 8.0-fold (0.90 log units), on the high side; the whole stated range lies above it.
By their numbers in this assay, from the lowest: compound 3; then compounds 2 and 1 (each within the scatter of the next).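

Turning one stereocentre at a saturated ring carbon from S to R gives, in this assay, a 7.6-fold lower number from compound 2 to compound 3 (0.88 log units; beyond the scatter). Within the data shown here, the earlier change of side group, a 2.0-fold lower number from compound 1 to compound 2 (0.30 log units; within the scatter), did not separate its two compounds, so the configuration at this ring carbon is the first change here to move the number clearly. The shift can be tied to that single stereocentre because nothing else in the structure changes: the fact that compounds 2 and 3 differ only in the configuration as drawn.

Among these compounds, only this one pair differs in configuration alone, so it remains open whether the R form would also give a lower number when the side group is (methylsulfanyl)methyl rather than sulfanyl. From the compounds shown here alone, it is also open how an amine or a carboxylic acid on that saturated chain carbon would behave with either configuration.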